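Compound 2 to compound 4: exchange on a sulfonamide nitrogen

The source may hold more compounds than are shown below. What is called first, only, known or untested is meant among the compounds shown, and "the series" means these compounds.

Of the compounds shown here, three with a shared core have numbers so far in a physicochemical assay for lipophilicity, at pH 7.4 (a lower number here means a more polar compound, a higher number a more lipophilic compound), and none of them is a single-place neighbour of another. Compound 1 (`O=S(=O)(c1ccc2c(c1)C(O)CC(C1CCOCC1)O2)N1CCC(c2ccccc2)CC1`) gives 2.63 and compound 3 (`CCc1ccc(NS(=O)(=O)c2ccc3c(c2)C(O)CC(C2CCOCC2)O3)cc1`) gives 2.59 with the two lying within the scatter of each other. Compound 2 (`CCS(=O)(=O)c1ccc(CN(CC(C)C)S(=O)(=O)c2ccc3c(c2)C(O)CC(C2CCOCC2)O3)nc1`) gives 1.42 and stands lowest of the three, beyond the scatter from both others.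

Compound 4 (`CC(C)CN(c1ccc(N(C)C)cc1)S(=O)(=O)c1ccc2c(c1)C(O)CC(C1CCOCC1)O2`) has no number yet. It departs from compound 2 on a sulfonamide nitrogen, where 4-(dimethylamino)phenyl comes in place of (5-(ethylsulfonyl)pyridin-2-yl)methyl (4-(dimethylamino)phenyl in place of (5-(ethylsulfonyl)pyridin-2-yl)methyl on a sulfonamide nitrogen). Among the measured compounds shown here, with no measured single-place step available, the size of this change in this assay can only be judged indirectly. Neither compound 1 at 2.63 nor compound 3 at 2.59 carries the (5-(ethylsulfonyl)pyridin-2-yl)methyl group, and compound 4 lacks it too, though three compounds are too few to establish a pattern. The estimated step, expected to lie beyond the scatter, is a number 1.58 log units higher from compound 2 to compound 4 (beyond the scatter) in the direction of a higher number. For compound 4 the expected value is 3 (estimated range 2.5 to 3.5).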

Compound 4, distribution coefficient: 3.51
Beside the measured number, compound 4's estimate is 0.51 log units below it, outside the stated range (above it).
By their numbers in this assay, from the lowest: compound 2; then compounds 3 and 1 (each within the scatter of the next); then compound 4.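

Notes on the sulfonamide nitrogen whose other neighbours are a saturated chain carbon and the sulfonyl sulfur: this position now gives the first single-place step in the series. In this assay, 4-(dimethylamino)phenyl in place of (5-(ethylsulfonyl)pyridin-2-yl)methyl gives a number 2.09 log units higher from compound 2 to compound 4 (beyond the scatter), so the group on this nitrogen can move the read-out by a large amount while the shared core stays unchanged. The exchange alters several counted features at once: 12 heavy atoms give way to 9, an aromatic ring with 1 hetero atom to one of carbon only, and 3 hydrogen-bond acceptors to 1, and no measurement here explains the step or divides it among these features.

Still open, from the compounds shown here alone, is which part of the exchange carries the step, and whether a plain benzyl or an unsubstituted phenyl on this nitrogen would fall closer to compound 2 or to compound 4. Also open, going by these compounds, is how far the number would move with a carboxylic acid or a morpholine on the phenyl ring in place of the dimethylamino group.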